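This account rests on a few compounds, and the source may have more. Where it says the series, first, only, none or still open, it means among the compounds named here.

Compound 3 `Nc1ncnc(Oc2ccc(NC(=O)C3(C(=O)Nc4ccc(F)cc4)CC3)cc2F)c1/C=N/OCCCN1CCCC1` stands highest among the three measured compounds in a physicochemical assay for lipophilicity, using the shake flask method (on this read-out higher numbers stand for higher lipophilicity and lower numbers for lower lipophilicity), at 3.82. Compound 1 `Nc1ncnc(Oc2ccc(NC(=O)C3(C(=O)Nc4ccc(F)cc4)CC3)cc2F)c1/C=N/OCCO` gives 2.37, and compound 2 `CCO/N=C/c1c(N)ncnc1Oc1ccc(NC(=O)C2(C(=O)Nc3ccc(F)cc3)CC2)cc1F` gives 3.41; the steps were a number 1.04 log units higher from compound 1 to compound 2 (beyond the scatter), a number 1.45 log units higher from compound 1 to compound 3 (beyond the scatter) and a number 0.41 log units higher from compound 2 to compound 3 (beyond the scatter). Compound 4 `Nc1ncnc(Oc2ccc(NC(=O)C3(C(=O)Nc4ccc(F)cc4)CC3)cc2F)c1/C=N/OCc1ccccc1` differs from compound 3 by phenyl in place of 2-(pyrrolidin-1-yl)ethyl on a saturated chain carbon bound to an oxygen. For the measured compounds named here, no measured step exchanges these two groups directly; the step from compound 2 to compound 3 shows only that lengthening the chain by the pyrrolidinyl group raised this assay modestly. Benzyloxy in place of 3-(pyrrolidin-1-yl)propoxy is expected to raise this assay further, so compound 4 is estimated at 5, within 4.4 to 5.6, a step of a number 1.18 log units higher from compound 3 to compound 4 (beyond the scatter).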

Compound 4, partition coefficient: 4.45
Beside the measured number, compound 4's estimate is 0.55 log units above it; low and high end bracket the measured number.
By their numbers in this assay, from the lowest: compound 1; then compound 2; then compound 3; then compound 4.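

On a saturated chain carbon bound to an oxygen, phenyl gives the highest number of the four compounds in this assay, with a number 0.63 log units higher from compound 3 to compound 4 (beyond the scatter), a number 1.04 log units higher from compound 2 to compound 4 (beyond the scatter) and a number 2.08 log units higher from compound 1 to compound 4 (beyond the scatter). For the compounds shown here, the earlier compounds carried only saturated chain ends here, so this is the first sign that an aromatic ring at this place outranks all of them, including the pyrrolidine-bearing chain. Nothing available explains this order. Still open, on these data alone, is how a pyridine ring or a longer 2-phenylethyl chain at this place would read in this assay.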